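Ethoxycarbonyl to Hydroxymethyl: What Compound 4 May Show

This account rests on a few compounds, and the source may have more. Where it says the series, first, only, none or still open, it means among the compounds named here.

Compound 1 `CCOC(=O)[C@]1(C(=O)Nc2ccccc2)C[C@@H]1c1cc(OC)c(OC)c(OC)c1` gives > 100000 nM in a functional assay on HeLa cells (Homo sapiens) for cytotoxicity, read by MTT assay, with a stated time of 48 h (a higher number here means a weaker inhibitor, a lower number a stronger inhibitor), which is a limit of the assay and not a number.
Compound 2 `CCOC(=O)[C@@]1(C(=O)Nc2ccccc2Cl)C[C@H]1c1cc(OC)c(OC)c(OC)c1` gives 14400 nM in this assay.
Compound 3 `COc1cc([C@H]2C[C@]2(CO)C(=O)Nc2ccccc2)cc(OC)c1OC` gives > 100000 nM in this assay, again a limit of the assay rather than a number.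

Among the compounds with values here, compound 2 is thus the only compound with a measured number; the other two sit at the limit of > 100000 nM in this assay, at which 2 of the 3 values shown sit. The difference between the cores of compound 1 and compound 2 is not broken down here. From compound 1 to compound 3 the change is hydroxymethyl in place of ethoxycarbonyl on a saturated ring carbon, and the step that the two limits leave unreadable from compound 1 to compound 3 is not readable. Compound 4 `COc1cc([C@@H]2C[C@@]2(CO)C(=O)Nc2ccccc2Cl)cc(OC)c1OC` carries the same change on the core of compound 2: hydroxymethyl in place of ethoxycarbonyl on a saturated ring carbon. The expectation for compound 4 in this assay rests on a single number, because compound 2 gives 14400 nM while the step that the two limits leave unreadable from compound 1 to compound 3 offers no guide. The step of a 2.8-fold higher number from compound 2 to compound 4 (0.44 log units; beyond the scatter) is expected to lean toward weaker inhibition, with a real chance that the assay reports only a limit. Compound 4 is estimated at 40000 nM, between 10000 nM and 150000 nM.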

Compound 4, half-maximal inhibitory concentration: 13300 nM
Estimate against measurement, compound 4: 3.0-fold (0.48 log units) above, and the stated range covers the measured number.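

On the core of compound 2, hydroxymethyl in place of ethoxycarbonyl on a saturated ring carbon gives a 1.1-fold lower number from compound 2 to compound 4 (0.03 log units; within the scatter) in this assay and so leaves the two compounds indistinguishable in this measurement. Going by these compounds, the same change on the core of compound 1 cannot be read, so it remains unknown whether the change behaves alike on both cores, because both ends of that step are limits of the assay and not numbers: the limit of > 100000 nM in this assay, at which 2 of the 4 values shown sit. This leaves one pair with a number on each side, which is a single observation on one core and not a rule for the series.

The compounds shown leave open whether an amine, a carboxylic acid or a longer chain on the same saturated ring carbon would also give a result in this assay that matches compound 2 and compound 4. Also open, on these data alone, is whether the hydroxymethyl result would hold on any core beyond these two.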